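The compounds below may be only part of what the source reports. "The series", "measured", "known", "first", "only" and "open" are said of these compounds alone.

Measured in a functional assay on L6 cells (Rattus norvegicus) for inhibition; on this read-out lower numbers stand for stronger inhibition and higher numbers for weaker inhibition:
- Compound 1 `CC(C)c1c(C(=O)NCc2ccccc2)nn(-c2ccc(F)cc2)c1OC[C@@H](O)C[C@@H](O)CC(=O)O`: 880 nM
- Compound 2 `Cc1ccc(CNC(=O)c2nn(-c3ccc(F)cc3)c(OC[C@@H](O)C[C@@H](O)CC(=O)O)c2C(C)C)cc1`: 2110 nM
- Compound 3 `COc1ccc(CNC(=O)c2nn(-c3ccc(F)cc3)c(OC[C@@H](O)C[C@@H](O)CC(=O)O)c2C(C)C)cc1`: "not determined" (no result reported)

Compound 3 therefore has no number to start from. Compound 4 `CC(C)c1c(C(=O)NCc2ccccc2Cl)nn(-c2ccc(F)cc2)c1OC[C@@H](O)C[C@@H](O)CC(=O)O` differs from it as follows: 2-chlorophenyl in place of 4-methoxyphenyl on a saturated chain carbon bound to an amide-type nitrogen. Within the data shown here, the only measured step, a 2.4-fold higher number from compound 1 to compound 2 (0.38 log units; beyond the scatter), is a modest one and comes from a different change, methyl in place of hydrogen on an aromatic carbon. Among the measured compounds shown here, it is only a rough guide, so no step from compound 3 can be sized. A modest difference from the measured compounds is expected, towards higher numbers if anything. In this assay the estimated value for compound 4 is 1300 nM, with an expected range of 400 nM to 4000 nM.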

Compound 4, half-maximal inhibitory concentration: 8450 nM
Estimate against measurement, compound 4: 6.5-fold (0.81 log units) below, outside the stated range (above it).
By their numbers in this assay, from the lowest: compound 1; then compound 2; then compound 4.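

In this assay compound 4 is the weakest inhibitor of the three with a number. Replacing 4-methylbenzyl with 2-chlorobenzyl gives a 4.0-fold higher number from compound 2 to compound 4 (0.60 log units; beyond the scatter) and adding chloro to the plain benzyl gives a 9.6-fold higher number from compound 1 to compound 4 (0.98 log units; beyond the scatter) in this series. Both substituted benzyl groups with a number therefore inhibit less well than plain benzyl, and nothing shown gives a cause for this.

Steps to compound 3 cannot be read, so the 4-methoxybenzyl group remains unsized. From the compounds shown here alone, whether a fluoro, hydroxyl or amine on the benzyl ring would behave the same way remains open.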